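Taking trifluoromethoxy off compound 2

The source may report more compounds than this note shows. Statements on the series, on what has been measured and on what is new or still open speak of the compounds shown alone.

Among the measured compounds shown here, in a functional assay on the whole organism with Rattus norvegicus as the target (a higher number here means that more compound is needed for the effect, a lower number that less compound is needed), compound 2 `CN(C)CCn1c(=N)sc2cc(OC(F)(F)F)ccc21` gives 2.3 mg/kg, the only actual number so far. For compound 1 `COC(=O)Cn1c(=N)sc2cc(OC(F)(F)F)ccc21`, > 10 mg/kg is a limit and not a number. For the measured compounds named here, the one measured step, an at least 4.3-fold lower number from compound 1 to compound 2 (0.63 log units; beyond the scatter), lies beyond the scatter, but it concerns the chain, so it bears only indirectly on compound 3 `CN(C)CCn1c(=N)sc2ccccc21`. That compound has hydrogen in place of trifluoromethoxy on an aromatic carbon. Going by the values given here, no measured step covers this change, so only a modest, uncertain rise from the value of compound 2 is expected. The expected step is a 2.2-fold higher number from compound 2 to compound 3 (0.34 log units; beyond the scatter). Compound 3 is estimated at 5 mg/kg, with an expected range of 1.5 mg/kg to 17 mg/kg.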

Compound 3, dose for half-maximal effect: > 10 mg/kg
Compound 3: a limit, no number (the forecaster's own chance of this, stated with the estimate: 30%); middle value at least 2.0-fold (0.30 log units) away from the limit.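

In this assay, the trifluoromethoxy group on this aromatic carbon now proves to matter in its own right: hydrogen in its place gives an at least 4.3-fold higher number from compound 2 to compound 3 (0.63 log units; beyond the scatter), so the dimethylamino chain of compound 2 alone does not carry the value. Going by these compounds, for compound 3, > 10 mg/kg is a limit and not a number, so the full size of the step stays unknown. Limits make up most of this small set: the limit of > 10 mg/kg in this assay, at which 2 of the 3 values shown sit.

On these data alone, whether chlorine, methoxy or trifluoromethyl on this carbon would keep the value of compound 2 stays open. So does the effect of a longer chain or a cyclic amine in place of the dimethylamino group.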